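From Sulfamoyl to Cyano on the Shared Core

A few compounds are considered here, and "the series" means these few. Any claim that something is new, unique, unknown or untested is made for them only; others in the source may bear on it.

Going by the values given here, in a functional assay on HT-29 cells (Homo sapiens) for antiproliferative activity, read by sulforhodamine B assay, with a stated time of 72 h (a lower number here means a stronger inhibitor, a higher number a weaker inhibitor), compound 1 `Fc1ccc(Nc2nncc3ccccc23)cc1` gives 2.1 nM, while compound 2 `NS(=O)(=O)c1ccc(Nc2nncc3ccccc23)cc1` gives 12 nM, the higher of the two numbers measured so far. Compound 3 `N#Cc1ccc(Nc2nncc3ccccc23)cc1` keeps the core of compound 2 but has cyano in place of sulfamoyl on an aromatic carbon, para to a large group: cyano in place of sulfamoyl on an aromatic carbon. Among the compounds with values here, only one measured step bears on this change, the exchange of fluoro for sulfamoyl at that carbon, which gave a 5.7-fold higher number from compound 1 to compound 2 (0.76 log units; beyond the scatter). Within the data shown here, no measured compound carries cyano, so this step offers only a loose guide. With sulfamoyl gone, part of that step is expected to be recovered, giving a modest move toward a lower number. The estimated step is a 2.4-fold lower number from compound 2 to compound 3 (0.38 log units; beyond the scatter). For compound 3, the estimated value is 5 nM, with an expected range of 1.5 nM to 20 nM.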

Compound 3, half-maximal inhibitory concentration: 1.2 nM
The estimate for compound 3 lay 4.2-fold (0.62 log units) above the measured number; the measured number lies below the stated range.
By their numbers in this assay, from the lowest: compounds 3 and 1 (each within the scatter of the next); then compound 2.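

In this assay, cyano in place of sulfamoyl on this aromatic carbon, para to a large group, gives a 10-fold lower number from compound 2 to compound 3 (1.00 log units; beyond the scatter) and so reverses the earlier 5.7-fold higher number from compound 1 to compound 2 (0.76 log units; beyond the scatter) rather than only part of it. Cyano and fluoro cannot be told apart here, with a 1.8-fold lower number from compound 1 to compound 3 (0.24 log units; within the scatter) within the scatter, which leaves sulfamoyl as the only one of the three groups whose number stands apart from both others at this position. The data offer no measurement that accounts for this difference.

Three groups at a single position cannot show whether sulfamoyl is an exception or whether others, such as an amine, a carboxylic acid or methylsulfonyl, would also give higher numbers. As far as these compounds go, it also remains open whether the same exchange would give a step of similar size on a core other than the shared one.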